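A few compounds are considered here, and "the series" means these few. Any claim that something is new, unique, unknown or untested is made for them only; others in the source may bear on it.

Working notes on the series. Three compounds have numbers in a functional assay on CHO cells for antagonist activity at Orexin/Hypocretin receptor type 1 (Homo sapiens), read by FLIPR and calcium flux; a lower number here means a less potent compound, a higher number a more potent compound, by a factor of ten per unit of this negative logarithm. Compound 1 `Cc1nc(C(=O)N2CC3(CC3)C[C@H]2CNc2ncc(Cl)cn2)c(-c2ccccc2)s1` gives 6.8 in this assay. Compound 2 `Cc1cc(C)nc(NC[C@@H]2CC3(CC3)CN2C(=O)c2nc(C)sc2-c2ccccc2)n1` gives 7.5 in this assay, the second highest of the three; its nearest neighbour on the numbers is compound 1, its furthest compound 3. For the measured compounds named here, compound 3 `Cc1cnn(-c2ccc(C)nc2C(=O)N2CC3(CC3)C[C@H]2CNc2ccc(C(F)(F)F)cn2)c1`, which carries a trifluoromethyl-bearing pyridine on the amine nitrogen and a different core, gives 8.9 in this assay; no single-place step links it to compound 2, so its number is noted only as the highest of the three.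

Going by the values given here, the one step that bears directly on the amine substituent is a number 0.70 log units higher from compound 1 to compound 2 (beyond the scatter). Compound 4 `Cc1cc(C(F)(F)F)cc(NC[C@@H]2CC3(CC3)CN2C(=O)c2nc(C)sc2-c2ccccc2)n1` is not yet measured; it differs from compound 2 in one place: 6-methyl-4-(trifluoromethyl)pyridin-2-yl in place of 4,6-dimethylpyrimidin-2-yl on an amine nitrogen

The change keeps the shape of a six-membered aromatic ring on the amine nitrogen while trading one hetero atom and a methyl for a trifluoromethyl. Among the compounds with values here, the only comparable measured step is the modest one from compound 1 to compound 2, and compound 3, with its own trifluoromethyl pyridine, sits highest. On that basis a modest rise is expected for compound 4, a number 0.40 log units higher from compound 2 to compound 4 (beyond the scatter), in this assay. The estimate for compound 4 is 7.9 in this assay, between 7.3 and 8.5.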

Compound 4, negative logarithm of the antagonist equilibrium constant: 7.8
Compound 4: the middle estimate sits 0.10 log units above what was measured; measured number inside the range.
By their numbers in this assay, from the lowest: compound 1; then compounds 2 and 4 (each within the scatter of the next); then compound 3.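

In this assay, 6-methyl-4-(trifluoromethyl)pyridin-2-yl on the amine nitrogen in place of 4,6-dimethylpyrimidin-2-yl gives a number 0.30 log units higher from compound 2 to compound 4 (within the scatter) so this position accepts a ring with one hetero atom and a trifluoromethyl with no difference that can be told from the scatter. Set against 5-chloropyrimidin-2-yl, the same group gives a number 1.00 log units higher from compound 1 to compound 4 (beyond the scatter) so among the three groups on this nitrogen over the shared core, 5-chloropyrimidin-2-yl alone stands apart. Nothing at hand says why these groups compare as they do.

The compounds shown leave open what the methyl and the trifluoromethyl each contribute alone, and what a phenyl ring carrying a nitrile or an acetyl group would give on this nitrogen. Compound 3 differs from the others in more than one place, so its number cannot be tied to the amine substituent.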